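Series notes: thiosuccinimide to succinimide swap at the aryl position

The compounds below may be only part of what the source reports. "The series", "measured", "known", "first", "only" and "open" are said of these compounds alone.

The series shares a core carried by compound 1 `CCc1cnc(N2CCC(c3nc(COc4c(F)cc(/C=C5\CC(=O)NC5=O)cc4F)cs3)CC2)nc1`, compound 2 `CCc1cnc(N2CCC(c3nc(COc4ccc(/C=C5\CC(=S)N(CC(=O)O)C5=O)cc4F)cs3)CC2)nc1` and compound 3 `CC(C)(C)OC(=O)N1CCC(c2nc(COc3c(F)cc(/C=C4\CC(=O)NC4=O)cc3F)cs2)CC1`. In a functional assay on cells for agonist activity at Glucose-dependent insulinotropic receptor (Homo sapiens), read by a luciferase reporter, with a stated time of 6 h (on this read-out higher numbers stand for an effect only at larger amounts of compound and lower numbers for an effect already at smaller amounts), compound 1 gives 211 nM. For compound 2 no result is reported in this assay, "not determined" (no result reported), and the same holds for compound 3, "not determined" (no result reported); so compound 2 stands without a number of its own, and only compound 1 anchors the series.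

Compound 4 `CCc1cnc(N2CCC(c3nc(COc4ccc(/C=C5\CC(=O)NC5=O)cc4F)cs3)CC2)nc1` has not been measured. It differs from compound 2 by the change (a group of 8 heavy atoms (5 carbon, 1 nitrogen, 2 oxygen; one five-membered non-aromatic ring with 1 hetero atom) in place of a group of 12 heavy atoms (7 carbon, 1 nitrogen, 3 oxygen, 1 sulfur; one five-membered non-aromatic ring with 1 hetero atom), on an aromatic carbon). The change sits on an aromatic carbon of a six-membered aromatic ring of carbon only, meta to a fluoro group and para to a large group. The part that leaves carries one five-membered non-aromatic ring with 1 hetero atom and 4 double bonds outside aromatic rings; the part that enters carries one five-membered non-aromatic ring with 1 hetero atom and 3 double bonds outside aromatic rings.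

No step between measured compounds is shown, so the size and direction of the step from compound 2 to compound 4 cannot be read from this data; the only hint is that compound 4 shares its entering group with compound 1. Compound 4 is expected to reach about 250 nM, within a range of 80 nM to 800 nM.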

Compound 4, half-maximal effective concentration: 49 nM
Compound 4: the middle estimate sits 5.1-fold (0.71 log units) above what was measured; measured number outside the range, below it.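

In this assay, going by these compounds alone, hydrogen in place of fluoro on an aromatic carbon gives a 4.3-fold lower number from compound 1 to compound 4 (0.63 log units; beyond the scatter), the first comparison between two compounds that differ in one place. This shows that the second fluoro group is not needed for activity on this read-out: with that group gone, compound 4 gives 49 nM, and the change moves the number in the lower direction by a modest step beyond the scatter. The step from compound 2 to compound 4 cannot be read, since compound 2 has no number, so the exchange of the five-membered ring groups remains without a size or direction, and no measurement at hand accounts for the effect of losing the fluoro group.

The compounds shown leave open how a chloro, methyl or methoxy group on that aromatic carbon would compare with hydrogen and fluoro, and whether the same step would appear with the tert-butyl carbamate of compound 3 in place of the ethyl-substituted end of the molecule. Also open, on these data alone, is what an amine or a longer chain on the nitrogen of the five-membered non-aromatic ring would do to the number.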